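Working notes on the step from compound 3 to compound 4

This account rests on a few compounds, and the source may have more. Where it says the series, first, only, none or still open, it means among the compounds named here.

Measured compounds:
compound 1 `C[C@H]1CC(Cl)=C([Si](C)(C)C)[C@@H](C2CCCCC2)O1` gives 62000 nM
compound 2 `C[C@@H]1O[C@H](C2CCCCC2)C([Si](C)(C)C)=C(Cl)[C@H]1C` gives 76000 nM
compound 3 `C[C@@H]1O[C@H](CCC=C(Br)Br)C([Si](C)(C)C)=C(Cl)[C@H]1C` gives 87000 nM

All three numbers come from a functional assay on SW1573 cells (Homo sapiens) for antiproliferative activity; a higher number here means that more compound is tolerated, a lower number that less compound is tolerated. Compound 3 sits with compound 1 and compound 2 in one narrow band: the gap to compound 2 and the gap to compound 1 are both within the scatter, so no order among the three can be read from them.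

Compound 4 `C#CCC[C@H]1O[C@@H](C)[C@H](C)C(Cl)=C1[Si](C)(C)C` is the next member. Against compound 3 the change is ethynyl in place of 2,2-dibromoethenyl on a saturated chain carbon, two bonds along the chain from a saturated ring carbon. Among the measured compounds shown here, two measured steps bear on it. The step of a 1.1-fold higher number from compound 2 to compound 3 (0.06 log units; within the scatter) exchanged the whole group on that saturated ring carbon and moved nothing beyond the scatter; the step of a 1.2-fold higher number from compound 1 to compound 2 (0.09 log units; within the scatter) elsewhere on the core was likewise flat. For the measured compounds named here, no measured pair alters the end of the chain itself, so the change from compound 3 to compound 4 has no direct precedent. Because a 1.1-fold higher number from compound 2 to compound 3 (0.06 log units; within the scatter) was flat for a far larger exchange at the same site, compound 4 is expected to show a 1.1-fold lower number from compound 3 to compound 4 (0.04 log units; within the scatter), no step beyond the scatter. For compound 4 the estimate in this assay is 80000 nM, with a range of 35000 nM to 180000 nM.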

Compound 4, concentration lethal to 50% of the cells: 75000 nM
For compound 4 the middle estimate is 1.1-fold (0.03 log units) above the measured one; low and high end bracket the measured number.
By their numbers in this assay, from the lowest: compounds 1, 4, 2 and 3 (each within the scatter of the next).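

In this assay, among the compounds shown here, the end of the chain is changed directly for the first time: ethynyl in place of 2,2-dibromoethenyl gives a 1.2-fold lower number from compound 3 to compound 4 (0.06 log units; within the scatter) and so leaves compound 4 in the same narrow band, even with the bromine atoms gone. The whole-group exchange at the saturated ring carbon now has a second reading, with but-3-yn-1-yl in place of cyclohexyl giving a 1.0-fold lower number from compound 2 to compound 4 (0.01 log units; within the scatter), so neither a cyclohexyl, a 4,4-dibromobut-3-en-1-yl nor a but-3-yn-1-yl group separates from the others in this assay. Nothing available explains this flatness.

As far as these compounds go, whether an amine or a carboxylic acid at the end of the chain, or a longer chain, would move the number out of this band remains open. From the compounds shown here alone, all four compounds also keep the trimethylsilyl and chloro groups on the shared core, so what replacing either of them would do is equally open.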